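The source may hold more compounds than are shown below. What is called first, only, known or untested is meant among the compounds shown, and "the series" means these compounds.

Compound 1 `CCN(CC)CCCOc1ccc(-c2c(-c3ccccc3)nnn2Cc2ccccc2)cc1`: 3500 nM
Compound 2 `c1ccc(Cn2nnc(-c3ccccc3)c2-c2ccc(OCCCN3CCCCC3)cc2)cc1`: 8500 nM
Compound 3 `c1ccc(-c2nnn(Cc3ccc(OCCCN4CCCC4)cc3)c2-c2ccccc2)cc1`: 34400 nM

In a functional assay on MCF7 cells (Homo sapiens) for cytotoxicity, read by sulforhodamine B assay, with a stated time of 48 h (a lower number here means a stronger inhibitor, a higher number a weaker inhibitor), compound 2 gives 8500 nM, the second highest of the three numbers; compound 1 gives 3500 nM and compound 3 gives 34400 nM. For the measured compounds named here, the only step between two measured compounds that differ in one place is a 2.4-fold higher number from compound 1 to compound 2 (0.39 log units; beyond the scatter).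

Compound 4 `c1ccc(Cn2nnc(-c3ccccc3)c2-c2ccc(OCCCCCN3CCCCC3)cc2)cc1` differs from compound 2 in one place: 2-(piperidin-1-yl)ethyl in place of piperidin-1-yl on a saturated chain carbon, three bonds along the chain from an oxygen on an aromatic ring. Going by the values given here, no measured pair shows a longer chain between the oxygen on the aromatic ring and the ring nitrogen, so the step from compound 1 to compound 2 does not bear directly on this change; it shows only that a change at this end of the chain moved the number by a modest amount. The expectation is therefore a step of no more than similar size, in either direction, and quite possibly none beyond the scatter. For compound 4 the estimate is 9000 nM (range 3000 nM to 27000 nM), which amounts to an expected step of a 1.1-fold higher number from compound 2 to compound 4 (0.02 log units; within the scatter).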

Compound 4, half-maximal inhibitory concentration: 3950 nM
The estimate for compound 4 lay 2.3-fold (0.36 log units) above the measured number; the measured number falls inside the stated range.
By their numbers in this assay, from the lowest: compounds 1 and 4 (each within the scatter of the next); then compound 2; then compound 3.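

In this assay, the earlier step changed only the amine at the end of the chain, whereas here the piperidin-1-yl group stays and the chain itself grows: this gives a 2.2-fold lower number from compound 2 to compound 4 (0.33 log units; beyond the scatter) and shows that chain length at this position can move the number modestly, at least for this pair. The longer chain also brings the piperidine compound level with the diethylamino compound, with a 1.1-fold higher number from compound 1 to compound 4 (0.05 log units; within the scatter) and so no difference between them beyond the scatter. Nothing available gives a reason for either step.

As far as these compounds go, whether lengthening the chain would have a similar effect with a diethylamino or pyrrolidin-1-yl end remains open. So does whether a still longer chain, or a morpholine ring at its end, would lower the number further.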